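The source may report more compounds than this note shows. Statements on the series, on what has been measured and on what is new or still open speak of the compounds shown alone.

Measured compounds:
- compound 1, `COc1cc(Cl)cc(-c2nn(-c3cccc(NC(=O)Nc4cccc(C(F)(F)F)c4)c3)cc2-c2ccncc2)c1`: 4.64%
- compound 2, `O=C(Nc1cccc(-n2cc(-c3ccncc3)c(-c3cc(O)cc(Cl)c3)n2)c1)Nc1ccc(Cl)c(Cl)c1`: -84.7%

In a functional assay on LOX IMVI cells (Homo sapiens) for inhibition, read by sulforhodamine B assay, with a stated time of 48 h, tested at 10 uM (on this read-out lower numbers stand for a stronger effect and higher numbers for a weaker effect at the one concentration tested), compound 1 gives 4.64% and stands highest of the two numbers; the nearest is compound 2, whose value of -84.7% lies well beyond the scatter below it. Among the measured compounds shown here, no single-point step between the two measured compounds is available, so only their two values can be compared.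

Compound 3, `COc1cc(Cl)cc(-c2nn(-c3cccc(NC(=O)Nc4ccc(Cl)c(Cl)c4)c3)cc2-c2ccncc2)c1`, is not yet measured. It is obtained from compound 1 by one change: 3,4-dichlorophenyl in place of 3-(trifluoromethyl)phenyl on an amide-type nitrogen. Compound 2 also carries a 3,4-dichlorophenyl group on its urea, and because compound 2 gives -84.7%, the entering group is not expected to harm the effect. The step from compound 1 to compound 3 is expected to go downward, that is toward a stronger effect, by a margin beyond the scatter, though the outcome is uncertain since the two measured compounds differ in more than one place. The expected step is a number 44.6 percentage points lower from compound 1 to compound 3 (beyond the scatter). Compound 3 is expected to give about -40%, within a range from -90% to 10%.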

Compound 3, a percentage reported as activity, at one concentration (the size of the read-out at that concentration, not a potency): 9.24%
Beside the measured number, compound 3's estimate is 49.2 percentage points below it; the measured number falls inside the stated range.
By their numbers in this assay, from the lowest: compound 2; then compounds 1 and 3 (each within the scatter of the next).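

In this assay, putting 3,4-dichlorophenyl in place of 3-(trifluoromethyl)phenyl on an amide-type nitrogen gives a number 4.6 percentage points higher from compound 1 to compound 3 (within the scatter), so with a methyl on the aromatic oxygen this position does not separate the two groups, even though they differ in their halogen atoms. The other single change is far larger: methyl in place of hydrogen on that oxygen, with the 3,4-dichlorophenyl group held constant, gives a number 93.9 percentage points higher from compound 2 to compound 3 (beyond the scatter). Of the two one-place steps now available, only the change at the oxygen goes beyond the scatter, and nothing available explains the size of that step.

On these data alone, it remains open whether the two groups on the amide-type nitrogen would also stay within the scatter of each other with a hydrogen on the oxygen, since one step on a single background cannot show that. As far as these compounds go, it is also open how much of the effect depends on that oxygen itself, and whether an ethyl group on it, or an amine in its place, would read like compound 2 or like compound 3.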